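The source may report more compounds than this note shows. Statements on the series, on what has been measured and on what is new or still open speak of the compounds shown alone.

Measured compounds:
compound 1, `NC(=O)c1c(NC(=O)c2ccccc2Cl)sc2c1CCN(C(=S)Nc1ccccc1F)C2`, 28700 nM
compound 2, `NC(=O)c1c(NC(=O)c2ccccc2Cl)sc2c1CCN(C(=S)Nc1ccccc1C(F)(F)F)C2`, 26700 nM

In a functional assay on HeLa cells (Homo sapiens) for antiproliferative activity, with a stated time of 24 h (a higher number here means a weaker inhibitor, a lower number a stronger inhibitor), compound 1 gives 28700 nM, the highest of the two numbers; the nearest is compound 2 with 26700 nM, and the step of a 1.1-fold lower number from compound 1 to compound 2 (0.03 log units; within the scatter) lies within the scatter. Compound 3, `NC(=O)c1c(NC(=O)c2ccccc2C(F)(F)F)sc2c1CCN(C(=S)Nc1ccccc1F)C2`, has not yet been measured. It differs from compound 1 in one place: trifluoromethyl in place of chloro on an aromatic carbon. For the measured compounds named here, the only measured step that bears on this is a 1.1-fold lower number from compound 1 to compound 2 (0.03 log units; within the scatter), which likewise brings in a trifluoromethyl group in place of a halogen, though at a different point of the shared core and starting from fluoro rather than chloro. That step did not move the number beyond the scatter, so for compound 3 in this assay no step beyond the scatter is expected in either direction. The different starting halogen and the different point of attachment leave room for uncertainty, so the range is set wide. Compound 3 is expected to give 27000 nM, within 12000 nM to 60000 nM. The expected step of a 1.1-fold lower number from compound 1 to compound 3 (0.03 log units; within the scatter) is accordingly small.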

Compound 3, half-maximal inhibitory concentration: > 50000 nM
Compound 3 gave a limit, no number; the forecaster's own chance of this, stated with the estimate: 5%; middle value at least 1.8-fold (0.26 log units) from the limit.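

In this assay compound 3 reaches a limit of the assay and not a number: the limit of > 50000 nM in this assay, at which 1 of the 3 values shown sits.

Going by these compounds, at the 2-chlorophenyl position, the change to 2-(trifluoromethyl)phenyl reads as an at least 1.7-fold higher number from compound 1 to compound 3 (0.24 log units; that floor lies within the scatter), so only a floor is known, the true size of the step stays open upward, and a real loss is not established. For the compounds shown here, the earlier pair showed trifluoromethyl in place of fluoro at the other substituted aromatic ring of the series, with a 1.1-fold lower number from compound 1 to compound 2 (0.03 log units; within the scatter); the new pair adds the first reading at this position, and it leaves room for the two positions to respond differently to trifluoromethyl without showing that they do.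

On these data alone, whether compound 3 truly stands apart from compound 1 remains open, since a limit cannot settle this and the series holds no value for compound 3 that could be compared directly. How this aromatic carbon tolerates groups other than the two halogen-bearing ones shown also remains open: a methoxy group, an amine or a carboxylic acid in place of chloro would extend the reading beyond chloro and trifluoromethyl.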